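Aryl in place of methyl on the ring amine nitrogen

The source may hold more compounds than are shown below. What is called first, only, known or untested is meant among the compounds shown, and "the series" means these compounds.

Compound 1 `CCCn1c(=O)[nH]c2nc(-c3ccc(S(=O)(=O)N4CCN(c5ccc(Cl)cc5F)CC4)cc3)[nH]c2c1=O` in an assay on CHO cells for displacement of a labelled ligand from adenosine receptor A1 (Homo sapiens), read by scintillation counting, with a stated time of 90 min, in the presence of a further agent that is not named here (a higher number here means a weaker inhibitor, a lower number a stronger inhibitor), gives only a limit, > 1000 nM. Compound 2 `CCCn1c(=O)[nH]c2nc(-c3ccc(S(=O)(=O)N4CCN(C)CC4)cc3)[nH]c2c1=O` gives 334 nM in this assay. Compound 3 `CCCn1c(=O)[nH]c2nc(-c3ccc(S(=O)(=O)N4CCN(Cc5cccc(Br)c5)CC4)cc3)[nH]c2c1=O` gives 928 nM in this assay.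

Among the two plain numbers, compound 2 stands lowest; its nearest neighbour is compound 3, with a 2.8-fold higher number from compound 2 to compound 3 (0.44 log units; beyond the scatter). The value of compound 1 is a limit and not a number (the limit of > 1000 nM in this assay, at which 1 of the 3 values shown sits).

Compound 4 `CCCn1c(=O)[nH]c2nc(-c3ccc(S(=O)(=O)N4CCN(c5cccc(F)c5)CC4)cc3)[nH]c2c1=O` differs from compound 2 in one place: 3-fluorophenyl in place of methyl on an amine nitrogen in a ring. Among the measured compounds shown here, two measured steps bear on this change. Going from the aryl group to methyl gave an at least 2.9-fold lower number from compound 1 to compound 2 (0.47 log units; beyond the scatter), so putting an aryl group back on that nitrogen in compound 4 is expected to move the number the other way, upward. The step from compound 1 to compound 3, an at least 1.0-fold lower number from compound 1 to compound 3 (0.03 log units; that floor lies within the scatter), shows an aryl-bearing group staying near the limit.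

For compound 4 a modest rise in this assay is therefore expected, a 2.7-fold higher number from compound 2 to compound 4 (0.43 log units; beyond the scatter). The estimate for compound 4 is 900 nM, with a range from 350 nM to 3000 nM, and a fair chance that only a limit is reported.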

Compound 4, inhibition constant: > 1000 nM
Compound 4 ended at the assay's limit; the forecaster's own chance of this, stated with the estimate: 40%; at least 1.1-fold (0.04 log units) between middle value and limit.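

In this assay, 3-fluorophenyl in place of methyl on the ring amine nitrogen gives an at least 2.9-fold higher number from compound 2 to compound 4 (0.47 log units; beyond the scatter), so a second aryl group, with a different halogen pattern from the 4-chloro-2-fluorophenyl of compound 1, also gives a weaker result than the methyl of compound 2. Compared with the 3-bromobenzyl group, the change gives an at least 1.0-fold higher number from compound 3 to compound 4 (0.03 log units; that floor lies within the scatter), which leaves the order of these two compounds unsettled, as that floor lies within the scatter. The step between the two aryl compounds cannot be read, and each of them gives only a limit of the assay, not a number: the limit of > 1000 nM in this assay, at which 2 of the 4 values shown sit.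

On these data alone, how far the two aryl compounds lie past that limit stays unknown, so nothing can be said about how the fluorine and chlorine on the aryl ring affect the result. As far as these compounds go, it also stays open whether a plain hydrogen, an ethyl group or a hydroxyethyl chain on that nitrogen would give a lower number than the methyl of compound 2, or whether a carboxylic acid carried there would give a higher one.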